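A few compounds are considered here, and "the series" means these few. Any claim that something is new, unique, unknown or untested is made for them only; others in the source may bear on it.

Measured in a functional assay on cells (leukaemia cell line, Homo sapiens) for inhibition, read by sulforhodamine B assay, with a stated time of 48 h; on this read-out higher numbers stand for weaker inhibition of growth and lower numbers for stronger inhibition of growth:
Compound 1 `O=S(=O)(Nc1ccc(F)c(Cl)c1)c1ccc(-c2cnc(C3CC3)o2)cc1`: 73700 nM
Compound 2 `O=S(=O)(Nc1cc(F)cc(F)c1)c1ccc(-c2cnc(C3CC3)o2)cc1`: 80000 nM

Compound 2 stands at 80000 nM, within the scatter of compound 1 at 73700 nM, so these two numbers do not separate the pair. Compound 3 `O=S(=O)(Nc1cc(F)cc(Cl)c1)c1ccc(-c2cnc(C3CC3)o2)cc1` keeps the shared core and the sulfonamide of compound 2 and changes one group: chloro in place of fluoro on an aromatic carbon. In words, this is chloro in place of fluoro on an aromatic carbon, turning 3,5-difluorophenyl into 3-chloro-5-fluorophenyl.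

Going by the values given here, one measured step bears on this: a 1.1-fold higher number from compound 1 to compound 2 (0.04 log units; within the scatter). That step also altered the halogens on the same phenyl group, putting 3,5-difluorophenyl in place of 3-chloro-4-fluorophenyl, and it stayed within the scatter. Among the compounds with values here, it is a single step, however, and no measured pair shows the exchange of fluoro for chloro at this place alone. No step beyond the scatter is therefore expected in this assay, in either direction. The expected step is a 1.1-fold lower number from compound 2 to compound 3 (0.05 log units; within the scatter). For compound 3 the estimated value is 72000 nM, with an expected range from 38000 nM to 125000 nM.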

Compound 3, concentration for total growth inhibition: 77500 nM
Compound 3: middle estimate off by 1.1-fold (0.03 log units), on the low side, within the range that was stated.
By their numbers in this assay, from the lowest: compounds 1, 3 and 2 (each within the scatter of the next).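

In this assay the exchange of fluoro for chloro, seen here alone on an aromatic carbon, gives a 1.0-fold lower number from compound 2 to compound 3 (0.01 log units; within the scatter) and so does not separate the two halogens at this place, meta to a fluoro group. With one chloro group present in both compounds, the comparison of the 3-chloro-5-fluorophenyl and 3-chloro-4-fluorophenyl groups on the sulfonamide nitrogen gives a 1.1-fold higher number from compound 1 to compound 3 (0.02 log units; within the scatter) and so does not separate these two arrangements either, which leaves all three halogen-bearing phenyl groups within the scatter of one another. Nothing available here accounts for this lack of separation.

Going by these compounds, all three compounds carry only halogens on this phenyl group, so it remains open whether a different kind of group at the same place, such as an amine, a methoxy group or a carboxylic acid, would give a step beyond the scatter. On these data alone, it also remains open whether the phenyl group would behave the same way without any halogen, and whether a longer chain in place of the cyclopropyl group on the shared core would move the number in this read-out.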